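A few compounds are considered here, and "the series" means these few. Any claim that something is new, unique, unknown or untested is made for them only; others in the source may bear on it.

Measured compounds:
compound 1 `COC(=O)C[C@H](NC(=O)OC(C)(C)C)C(=O)N(Cc1ccccc1)C1(C(=O)NCc2ccccc2)CCN(Cc2ccccc2)CC1` — 20000 nM
compound 2 `CC[C@H](C)[C@H](NC(=O)OC(C)(C)C)C(=O)N(Cc1ccccc1)C1(C(=O)NCc2ccccc2)CCN(Cc2ccccc2)CC1` — 10000 nM
compound 3 `CCC(C)N(C(=O)[C@H](CC(=O)OC)NC(=O)OCc1ccccc1)C1(C(=O)NCc2ccccc2)CCN(Cc2ccccc2)CC1` — 4300 nM

In a functional assay on HeLa cells (Homo sapiens) for inhibition, with a stated time of 72 h (on this read-out higher numbers stand for weaker inhibition and lower numbers for stronger inhibition), compound 1 gives 20000 nM. The change from compound 1 to compound 2 is sec-butyl in place of (methoxycarbonyl)methyl on a saturated chain carbon bound to an amide-type nitrogen and a carbonyl carbon, and it made a 2.0-fold lower number from compound 1 to compound 2 (0.30 log units; within the scatter). Compound 3 has the same atoms as compound 1 joined differently; the difference between the two cores is not broken down here. In this assay compound 3 gives 4300 nM, the lowest of the three numbers.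

Compound 4 `CCC(C)N(C(=O)[C@@H](NC(=O)OCc1ccccc1)[C@@H](C)CC)C1(C(=O)NCc2ccccc2)CCN(Cc2ccccc2)CC1` has not been measured. It differs from compound 3 by sec-butyl in place of (methoxycarbonyl)methyl on a saturated chain carbon bound to an amide-type nitrogen and a carbonyl carbon, the same change that was made from compound 1 to compound 2, at the same place. A step of about the same size is expected, so a 2.0-fold lower number from compound 3 to compound 4 (0.29 log units; within the scatter) is estimated, resting on a 2.0-fold lower number from compound 1 to compound 2 (0.30 log units; within the scatter). Compound 4 is therefore expected to give about 2200 nM in this assay, within 900 nM to 5500 nM.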

Compound 4, half-maximal inhibitory concentration: 119000 nM
For compound 4 the middle estimate is 54-fold (1.73 log units) below the measured one, and the stated range ends below it.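

In this assay, putting sec-butyl in place of (methoxycarbonyl)methyl gave a 28-fold higher number from compound 3 to compound 4 (1.44 log units; beyond the scatter). This change therefore does not carry over between these two cores, and a step seen on one core is a poor guide to the step on the other: the same change on two cores in this assay, a 2.0-fold lower number (0.30 log units; within the scatter) from compound 1 to compound 2 and a 28-fold higher number (1.44 log units; beyond the scatter) from compound 3 to compound 4, 55-fold (1.74 log units) apart, beyond the scatter of two such steps. These two pairs show that the core matters, but they do not show which part of the core is responsible, why the outcome differs, or how the change would behave on any third core.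

The compounds shown leave open how a chain ending in a carboxylic acid or an amine would behave at this place. They also leave open whether either would follow compound 3 or compound 4 more closely.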